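Cinnamamide replaces quinoline amide in a bisindole nitrile series

This account rests on a few compounds, and the source may have more. Where it says the series, first, only, none or still open, it means among the compounds named here.

The series shares one core carrying a nitrile and an aminomethyl arm, and varies the acyl group on that arm. Compound 1 `CN1[C@@H]2c3[nH]c4ccccc4c3C[C@H]1[C@H](C#N)N1[C@@H](CN3C(=O)c4ccccc4C3=O)c3[nH]c4ccccc4c3C[C@@H]21` carries a phthalimide and gives 80 nM in a functional assay on HT-29 cells (Homo sapiens) for cytotoxicity, read by MTT assay, with a stated time of 72 h; a lower number here means a stronger inhibitor, a higher number a weaker inhibitor. Compound 2 `CN1[C@@H]2c3[nH]c4ccccc4c3C[C@H]1[C@H](C#N)N1[C@@H](CNC(=O)c3cccc(C(F)(F)F)c3)c3[nH]c4ccccc4c3C[C@@H]21` carries a 3-(trifluoromethyl)phenyl amide and gives 140 nM. Compound 3 `CN1[C@@H]2c3[nH]c4ccccc4c3C[C@H]1[C@H](C#N)N1[C@@H](CNC(=O)c3ccc4ccccc4n3)c3[nH]c4ccccc4c3C[C@@H]21` carries a quinolin-2-yl amide and gives 150 nM. Compound 3 lies within the usual scatter of both others: compound 2 is nearest, compound 1 furthest, so nothing separates the three beyond the noise of repeated measurement.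

Compound 4 `COc1ccc(/C=C/C(=O)NC[C@H]2c3[nH]c4ccccc4c3C[C@H]3[C@H]4c5[nH]c6ccccc6c5C[C@@H]([C@H](C#N)N23)N4C)cc1` is the next member, not yet measured. It differs from compound 3 in one place: 2-(4-methoxyphenyl)ethenyl in place of quinolin-2-yl on a carbonyl carbon. For the measured compounds named here, the only measured step that bears on this position is a 1.1-fold higher number from compound 2 to compound 3 (0.03 log units; within the scatter), a swap of one aromatic acyl group for another that left the number essentially unchanged; the gap from compound 1 to compound 3 is likewise within the scatter. Three different acyl groups on this arm have therefore given numbers that cannot be told apart.

On that basis the step of no change at the digits printed from compound 3 to compound 4 (within the scatter) is expected to stay within the scatter, with no clear direction. Compound 4 is estimated at 150 nM, with a range from 70 nM to 330 nM.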

Compound 4, half-maximal inhibitory concentration: 3060 nM
For compound 4 the middle estimate is 20-fold (1.31 log units) below the measured one; measured number outside the range, above it.
By their numbers in this assay, from the lowest: compounds 1, 2 and 3 (each within the scatter of the next); then compound 4.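

In this assay this acyl position proves not to be indifferent: a 20-fold higher number from compound 3 to compound 4 (1.31 log units; beyond the scatter) and a 22-fold higher number from compound 2 to compound 4 (1.34 log units; beyond the scatter) are large steps beyond the scatter, whereas the swap of one aromatic acyl group for another, a 1.1-fold higher number from compound 2 to compound 3 (0.03 log units; within the scatter), stayed within it. The change on the carbonyl carbon leaves the number of heavy atoms and the counts of hydrogen-bond donors and acceptors as they were, so these counts do not separate compound 3 from compound 4; what does differ is that the entering 2-(4-methoxyphenyl)ethenyl group has a double bond outside aromatic rings, an oxygen where quinolin-2-yl has a nitrogen, and no six-membered aromatic ring with a hetero atom. No measurement at hand accounts for the large rise in the number.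

The compounds shown leave open whether the double bond or the methoxy group goes with the step, as the two enter together in compound 4. A plain 2-phenylethenyl group and a saturated 2-(4-methoxyphenyl)ethyl chain on the same carbonyl carbon would each separate one from the other.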